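This account rests on a few compounds, and the source may have more. Where it says the series, first, only, none or still open, it means among the compounds named here.

Compound 1 `CC(C)Cc1ccc(C(C)C(=O)NCc2ccccc2)cc1`: 21000 nM
Compound 2 `CC(C)Cc1ccc(C(C)C(=O)NCc2ccc(Cl)cc2)cc1`: 27000 nM
Compound 3 `CC(C)Cc1ccc(C(C)C(=O)NCc2ccc(C(C)(C)C)cc2)cc1`: 25000 nM

In an assay on brain for inhibition of Fatty-acid amide hydrolase 1 (Rattus norvegicus), read by scintillation counting, with a stated time of 10 min (a lower number here means a stronger inhibitor, a higher number a weaker inhibitor), compound 3 sits with its two neighbours: a 1.2-fold higher number from compound 1 to compound 3 (0.08 log units; within the scatter) and a 1.1-fold lower number from compound 2 to compound 3 (0.03 log units; within the scatter), so all three numbers lie within the usual scatter of one another. Compound 4 `CC(C)Cc1ccc(C(C)C(=O)NCc2ccc(C(F)(F)F)cc2)cc1` differs from compound 3 by trifluoromethyl in place of tert-butyl on an aromatic carbon. Among the compounds with values here, the steps that bear on this are the exchanges at the same aromatic carbon, a 1.2-fold higher number from compound 1 to compound 3 (0.08 log units; within the scatter) and a 1.1-fold lower number from compound 2 to compound 3 (0.03 log units; within the scatter), and also a 1.3-fold higher number from compound 1 to compound 2 (0.11 log units; within the scatter); none of them moved the number beyond the scatter. No step beyond the scatter is therefore expected here either, and the expected step of no change at the digits printed from compound 3 to compound 4 (within the scatter) is small. Compound 4 is estimated at 25000 nM, with a range from 12000 nM to 50000 nM.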

Compound 4, half-maximal inhibitory concentration: 51000 nM
Beside the measured number, compound 4's estimate is 2.0-fold (0.31 log units) below it; measured number above the stated range.
By their numbers in this assay, from the lowest: compounds 1, 3, 2 and 4 (each within the scatter of the next, the first and the last beyond it).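

In this assay, of the groups shown on this aromatic carbon only trifluoromethyl moves the number beyond the scatter, toward a weaker inhibitor, with a 2.0-fold higher number from compound 3 to compound 4 (0.31 log units; beyond the scatter) and a 2.4-fold higher number from compound 1 to compound 4 (0.39 log units; beyond the scatter), both modest. Against chloro the same group stays within the scatter, with a 1.9-fold higher number from compound 2 to compound 4 (0.28 log units; within the scatter), so the position is not equally tolerant of every exchange, though the shift is small. Nothing available explains this shift. As far as these compounds go, whether an amine or a carboxylic acid on this aromatic carbon would give a lower number or a higher one remains open.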